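Swapping an open amide chain for a cyclic sulfonamide

The compounds below may be only part of what the source reports. "The series", "measured", "known", "first", "only" and "open" are said of these compounds alone.

The three compounds here share one core, seen in compound 1 `Brc1nn(-c2ccc3ncccc3c2)c2nc(Nc3cnn(C4CCNCC4)c3)ncc12`. Compound 2 `COCCNC(=O)CCNc1ncc2c(Br)nn(-c3ccc4ncccc4c3)c2n1` and compound 3 `COCc1noc([C@@H]2CC[C@@H](Nc3ncc4c(Br)nn(-c5ccc6ncccc6c5)c4n3)C2)n1` keep that core and vary the group on the nitrogen attached to the aromatic ring. Activity was followed in an assay on SK-OV-3 cells for inhibition of eIF-2-alpha kinase GCN2 (Homo sapiens); a higher number here means a weaker inhibitor, a lower number a stronger inhibitor. Compound 1 gives 610 nM in this assay. For compound 2 the record holds only "nd" (no result reported), meaning no figure was reported, and the same is true of compound 3, whose entry is "nd" (no result reported). So compound 2 stands without any number of its own, and the single measured value among these compounds belongs to compound 1.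

The step to compound 4 `CS(=O)(=O)N1CC[C@@H](Nc2ncc3c(Br)nn(-c4ccc5ncccc5c4)c3n2)C1` changes only the substituent on that nitrogen: 1-(methylsulfonyl)pyrrolidin-3-yl in place of 2-((2-methoxyethyl)carbamoyl)ethyl on a nitrogen on an aromatic ring. Because compound 2 carries no value, nothing about the size or direction of this step can be read from measured pairs; the expectation can rest only on compound 1 at 610 nM, which shares the core and a cyclic amine-bearing group at the same nitrogen. With that as the sole anchor, compound 4 is expected to land near 800 nM in this assay, with a wide range from 150 nM to 4000 nM.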

Compound 4, half-maximal inhibitory concentration: 378 nM
Estimate against measurement, compound 4: 2.1-fold (0.33 log units) above; the range from low to high includes it.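

No step can be read from the result for compound 4: compound 2, the compound it differs from in one place, holds no number in this assay to compare with. As far as these compounds go, whether 2-((2-methoxyethyl)carbamoyl)ethyl or 1-(methylsulfonyl)pyrrolidin-3-yl gives the stronger inhibitor on this core stays open. No supporting information bears on the value of compound 4.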